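Working notes: from compound 3 to compound 4

The source may hold more compounds than are shown below. What is called first, only, known or untested is meant among the compounds shown, and "the series" means these compounds.

Measured in a functional assay on HT-29 cells (Homo sapiens) for cytotoxicity, read by MTT assay, with a stated time of 24 h, tested at 16 ug/mL; a lower number here means a weaker effect, a higher number a stronger effect of the compound at the concentration tested:
compound 1 `CN(C)/C=C/N1CCN(CC(=O)Nc2ccc(-c3nc(-c4ccccc4)c(-c4ccccc4)n3C)cc2)CC1` gives 28.2%
compound 2 `Cn1c(-c2ccc(NC(=O)CN3CCN(c4ccccc4)CC3)cc2)nc(-c2ccccc2)c1-c1ccccc1` gives 55.4%
compound 3 `Cn1c(-c2ccc(NC(=O)CN3CCN(Cc4ccccc4)CC3)cc2)nc(-c2ccccc2)c1-c1ccccc1` gives 37%

Compound 3 holds the second highest of the three numbers; its nearest neighbour is compound 1, a gap within the scatter, and its furthest is compound 2, a gap beyond the scatter. Compound 4 `Cc1ccc(CN2CCN(CC(=O)Nc3ccc(-c4nc(-c5ccccc5)c(-c5ccccc5)n4C)cc3)CC2)cc1` differs from compound 3 by methyl in place of hydrogen on an aromatic carbon. Among the measured compounds shown here, no measured step touches this ring carbon. The closest comparisons replace the whole group on the amine nitrogen in the ring: a number 18.4 percentage points lower from compound 2 to compound 3 (beyond the scatter) and a number 8.8 percentage points higher from compound 1 to compound 3 (within the scatter), one modest and one within the scatter. The present change is one carbon with no ring, smaller than either, so no step beyond the scatter is expected in this assay, in either direction. Compound 4 is therefore expected to give 38%, with a range from 24% to 52%. The step of a number 1 percentage points higher from compound 3 to compound 4 (within the scatter) is expected to lie within the scatter.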

Compound 4, a percentage reported as activity, at one concentration (the size of the read-out at that concentration, not a potency): 30.6%
For compound 4 the middle estimate is 7.4 percentage points above the measured one, within the range that was stated.
By their numbers in this assay, from the lowest: compounds 1, 4 and 3 (each within the scatter of the next); then compound 2.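

In this assay, methyl on this aromatic carbon gives a number 6.4 percentage points lower from compound 3 to compound 4 (within the scatter) and so no readable change from hydrogen at this ring position. With 4-methylbenzyl on the ring amine nitrogen, the gap to the phenyl group remains, at a number 24.8 percentage points lower from compound 2 to compound 4 (beyond the scatter), while the comparison with 2-(dimethylamino)ethenyl gives a number 2.4 percentage points higher from compound 1 to compound 4 (within the scatter) and again no readable change. No measurement shown accounts for these steps.

From the compounds shown here alone, whether methoxy, chlorine or a carboxylic acid at this ring carbon would move the read-out beyond the scatter remains open. So does whether methyl on the phenyl group of compound 2 would leave its read-out unchanged.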